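This account rests on a few compounds, and the source may have more. Where it says the series, first, only, none or still open, it means among the compounds named here.

Measured compounds in a functional assay on cells (Leukemia cell, Homo sapiens) for inhibition; on this read-out higher numbers stand for weaker inhibition of growth and lower numbers for stronger inhibition of growth:
compound 1 `N=C(N)N/N=C/c1c(-c2ccsc2)nc2sccn12` gives 6920 nM
compound 2 `Cc1cc(-c2nc3sccn3c2/C=N/NC(=N)N)c(C)s1` gives 15500 nM
compound 3 `N=C(N)N/N=C/c1c(-c2ccsc2)nc2n1CCS2` gives 19100 nM

Within this set one matched change is seen: 2,5-dimethylthiophen-3-yl in place of thiophen-3-yl on an aromatic carbon. It gave a 2.2-fold higher number from compound 1 to compound 2 (0.35 log units; beyond the scatter). Compound 3 has a different core from compound 1; the difference between the two cores is not broken down here. In this assay compound 3 lies higher than compound 1, whereas compound 3 and compound 2 fall within the usual scatter of each other.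

Compound 4 `Cc1cc(-c2nc3n(c2/C=N/NC(=N)N)CCS3)c(C)s1` has not been measured. It carries the same kind of change on the core of compound 3: 2,5-dimethylthiophen-3-yl in place of thiophen-3-yl on an aromatic carbon. The surroundings are not identical word for word: for compound 3 to compound 4 the place is in addition two ring bonds from two ring atoms that each bear a fused ring. The expected step is a 2.2-fold higher number from compound 3 to compound 4 (0.34 log units; beyond the scatter), set beside a 2.2-fold higher number from compound 1 to compound 2 (0.35 log units; beyond the scatter) on the assumption that the change carries over, which rests on one pair only. Compound 4 is therefore estimated at 42000 nM, with a range of 16000 nM to 110000 nM.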

Compound 4, concentration for 50% growth inhibition: 20900 nM
Estimate against measurement, compound 4: 2.0-fold (0.30 log units) above; the measured number falls inside the stated range.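

In this assay, 2,5-dimethylthiophen-3-yl in place of thiophen-3-yl on the core of compound 3 gives a 1.1-fold higher number from compound 3 to compound 4 (0.04 log units; within the scatter), and the two steps for this change do not differ beyond the scatter: the same change on two cores in this assay, a 2.2-fold higher number (0.35 log units; beyond the scatter) from compound 1 to compound 2 and a 1.1-fold higher number (0.04 log units; within the scatter) from compound 3 to compound 4, 2.0-fold (0.31 log units) apart, within the scatter of two such steps

The two pairs are therefore compatible with the change carrying over from one core to the other. Within the data shown here, they do not establish a common size for it, since only the step on the core of compound 1 lies beyond the scatter and each core rests on one pair.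

Still open, as far as these compounds go, is whether a phenyl ring, or a thiophen-3-yl bearing a carboxylic acid or an amine, would give matching steps on both cores. Also open, from the compounds shown here alone, is whether a single methyl on the thiophen-3-yl would do so.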